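Shifting a Chloro Group on the Shared Core

The compounds below may be only part of what the source reports. "The series", "measured", "known", "first", "only" and "open" are said of these compounds alone.

Compound 1 `COc1cc2c(/C=C3/C(=O)Nc4ccc(O)cc43)c(Cl)n(Cc3cc(OC)c(OC)c(OC)c3)c2cc1C` was tested in a functional assay on cells (Cancer cell lines, Homo sapiens) for cytotoxicity, with a stated time of 48 h (a lower number here means a stronger inhibitor of growth, a higher number a weaker inhibitor of growth), where compound 1 gives 2040 nM. Among the three compounds measured, this is the lowest number, though the gap to compound 2 `COc1cc2c(/C=C3/C(=O)Nc4ccc(Cl)cc43)c(Cl)n(Cc3cc(OC)c(OC)c(OC)c3)c2cc1C`, which gives 2340 nM, is within the scatter, as the step of a 1.1-fold higher number from compound 1 to compound 2 (0.06 log units; within the scatter) shows. Compound 3 `O=C1/C(=C/c2c(Cl)[nH]c3ccccc23)c2ccccc2N1Cc1ccccc1`, giving 4900 nM, lies beyond the scatter from compound 1.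

Compound 4 `COc1cc2c(/C=C3/C(=O)Nc4cccc(Cl)c43)c(Cl)n(Cc3cc(OC)c(OC)c(OC)c3)c2cc1C` differs from compound 1 in one place: a group of 12 heavy atoms (9 carbon, 1 nitrogen, 1 oxygen, 1 chlorine; one five-membered non-aromatic ring with 1 hetero atom, one six-membered aromatic ring of carbon only) in place of a group of 12 heavy atoms (9 carbon, 1 nitrogen, 2 oxygen; one five-membered non-aromatic ring with 1 hetero atom, one six-membered aromatic ring of carbon only), on an aromatic carbon. Within the data shown here, only the step from compound 1 to compound 2 bears on this change, and it shows that swapping the hydroxy for a chloro group left the number essentially unchanged. Among the measured compounds shown here, compound 4 carries the chloro group at a different position of the same ring, for which no measured step exists, so the expectation rests on the single neighbouring comparison.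

The step from compound 1 to compound 4 is therefore expected to be small, a 1.1-fold higher number from compound 1 to compound 4 (0.05 log units; within the scatter), with no clear direction. Compound 4 is estimated to give 2300 nM, with a range from 1200 nM to 4600 nM.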

Compound 4, concentration for 50% growth inhibition: 3020 nM
Estimate against measurement, compound 4: 1.3-fold (0.12 log units) below, within the range that was stated.
By their numbers in this assay, from the lowest: compounds 1, 2, 4 and 3 (each within the scatter of the next, the first and the last beyond it).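

Moving the chloro group to a different place on the same ring gives the first direct test of its placement on the shared core, and the step of a 1.3-fold higher number from compound 2 to compound 4 (0.11 log units; within the scatter) in this assay does not separate the two placements. The comparison with the hydroxy-bearing parent, a step of a 1.5-fold higher number from compound 1 to compound 4 (0.17 log units; within the scatter) on the same read-out, also stays small, so neither this swap nor this shift moves the number measurably among these compounds. No measurement is available to explain why these numbers stay so close.

From the compounds shown here alone, only hydroxy and chloro are compared on this ring, so it remains open whether a methoxy group, an amine or a carboxylic acid would give a similar number. The compounds also leave open whether a second chloro group on this ring would change the result.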